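Benzylamino nucleoside analogues at the antiproliferative assay ceiling

The source may report more compounds than this note shows. Statements on the series, on what has been measured and on what is new or still open speak of the compounds shown alone.

Compound 1, `Cc1cccc(CNc2ncnc3c2ncn3[C@@H]2O[C@H](CO)[C@@H](O)[C@H]2O)c1`, in a functional assay on HOS cells (Homo sapiens) for antiproliferative activity, with a stated time of 72 h; a lower number here means a stronger inhibitor, a higher number a weaker inhibitor: > 166000 nM
Compound 2, `COc1cccc(CNc2ncnc3c2ncn3[C@@H]2O[C@H](CO)[C@@H](O)[C@H]2O)c1`, in this assay: > 166000 nM
Compound 3, `OC[C@H]1O[C@@H](n2cnc3c(NCc4cc(F)cc(F)c4)ncnc32)C(O)C1O`, in this assay: "not determined" (no result reported)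

The account follows the step from compound 2 to compound 4. In this assay compound 2 reaches only a limit of the assay, > 166000 nM, and no number. Compound 1 sits at the same limit, > 166000 nM. For compound 3 no result was reported. Going by the values given here, the single step between measured compounds, a step that the two limits leave unreadable from compound 1 to compound 2, is therefore unreadable, and the one piece of evidence available is the limit of > 166000 nM in this assay, at which 2 of the 3 values shown sit.

Compound 4, `OC[C@H]1O[C@@H](n2cnc3c(NCc4ccc(F)c(Cl)c4)ncnc32)[C@H](O)[C@@H]1O`, has not yet been measured in this assay. It differs from compound 2 as follows: 3-chloro-4-fluorophenyl in place of 3-methoxyphenyl on a saturated chain carbon bound to a nitrogen on an aromatic ring. No measured step bears on this exchange, since the only step shown cannot be read in either direction.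

Because both compound 1 and compound 2 sit at the limit of > 166000 nM in this assay, at which 2 of the 3 values shown sit, compound 4 is expected to remain at that ceiling as well, with the step of a number no higher from compound 2 to compound 4 (the limit leaves the size open) expected to be no more than the scatter. The estimate for compound 4 in this assay is 166000 nM, ranging from 40000 nM to 600000 nM, with a strong chance that only a limit is reported again.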

Compound 4, half-maximal inhibitory concentration: > 166000 nM
Compound 4 gave a limit, no number (the forecaster's own chance of this, stated with the estimate: 80%); the middle value lies on the limit itself.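

Compound 4 also gives only a limit in this assay, so its steps from compound 1 and from compound 2 cannot be read, and all three compounds rest on the same limit: the limit of > 166000 nM in this assay, at which 3 of the 4 values shown sit.

The compounds shown leave open how the 3-methylphenyl, 3-methoxyphenyl and 3-chloro-4-fluorophenyl groups would rank, since none of the three compounds gives a number.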